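The compounds below may be only part of what the source reports. "The series", "measured", "known", "first", "only" and "open" are said of these compounds alone.

Of the compounds shown here, three have been measured in a functional assay on QGY cells (Homo sapiens) for cytotoxicity, read by MTT assay, with a stated time of 48 h; on this read-out lower numbers stand for stronger inhibition and higher numbers for weaker inhibition. Compound 1 `COc1cc([C@H]2C[C@@]2(CO)C(=O)Nc2ccccc2)cc(OC)c1OC` is reported only as a limit, > 100000 nM. Compound 2 `COc1cc([C@H]2C[C@]2(CO)C(=O)Nc2ccccc2Cl)cc(OC)c1OC` gives 40700 nM. Compound 3 `COc1cc([C@H]2C[C@]2(CO)C(=O)NCc2ccc(C)cc2)cc(OC)c1OC` gives 56100 nM, which lies within the scatter of the value for compound 2, so the two numbers cannot be told apart.

Compound 4 `COc1cc([C@H]2C[C@]2(CO)C(=O)Nc2ccccc2)cc(OC)c1OC` has not yet been measured. It differs from compound 3 by phenyl in place of 4-methylbenzyl on an amide-type nitrogen.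

Among the measured compounds shown here, one measured step bears on this change, since it also swaps the group on an amide-type nitrogen, putting 4-methylbenzyl in place of 2-chlorophenyl. That step is a 1.4-fold higher number from compound 2 to compound 3 (0.14 log units; within the scatter). For the measured compounds named here, with only this step as a guide, no change beyond the scatter is expected in this assay, and the direction remains open. The estimated step is a 1.1-fold higher number from compound 3 to compound 4 (0.03 log units; within the scatter). For compound 4 the expected value is 60000 nM, with an estimated range from 30000 nM to 120000 nM.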

Compound 4, half-maximal inhibitory concentration: > 100000 nM
Compound 4 was reported as a limit; the forecaster's own chance of this, stated with the estimate: 30%; middle value at least 1.6-fold (0.22 log units) from the limit.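

In this assay, among the compounds shown here, hydrogen in place of chloro on an aromatic carbon gives an at least 2.4-fold higher number from compound 2 to compound 4 (0.39 log units; beyond the scatter), so the chloro group of compound 2 marks a difference that the earlier compounds could not show. Phenyl in place of 4-methylbenzyl on an amide-type nitrogen gives an at least 1.7-fold higher number from compound 3 to compound 4 (0.25 log units; that floor lies within the scatter); the direction is now shown, but the floor alone does not separate the two compounds. The step between compound 1 and compound 4 cannot be read, because both are reported only as limits: the limit of > 100000 nM in this assay, at which 2 of the 4 values shown sit.

As far as these compounds go, whether configuration changes the read-out in this pair stays open: the fact that compounds 1 and 4 differ only in the configuration as drawn Also open is how an amine, a carboxylic acid or a longer chain in place of phenyl on an amide-type nitrogen would read in this assay.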